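Swapping the nitrogen substituent in a cytotoxicity series

The source may report more compounds than this note shows. Statements on the series, on what has been measured and on what is new or still open speak of the compounds shown alone.

Compound 1 `Cc1ccc(-c2c(C)c(-c3ccc(C)c(C)c3)c(C(OC(C)(C)C)C(=O)O)c(C)c2NS(C)(=O)=O)cc1C` gives 15000 nM in an ADME assay on MT4 cells (Homo sapiens) for cytotoxicity, read by MTT assay, with a stated time of 4 days; a lower number here means that less compound is tolerated, a higher number that more compound is tolerated.
Compound 2 `CCC(=O)Nc1c(C)c(C(OC(C)(C)C)C(=O)O)c(-c2ccc(C)c(C)c2)c(C)c1-c1ccc(C)c(C)c1` gives 15000 nM in this assay.

Compound 2 stands level with compound 1, since no change at the digits printed from compound 1 to compound 2 (within the scatter). Compound 3 `Cc1ccc(-c2c(C)c(-c3ccc(C)c(C)c3)c(C(OC(C)(C)C)C(=O)O)c(C)c2NCc2ccccc2)cc1C` differs from compound 2 by benzyl in place of propanoyl on a nitrogen on an aromatic ring. Going by the values given here, the only measured step, from compound 1 to compound 2, also changed the group on this nitrogen and left the read-out unchanged, so no step beyond the scatter is expected here either. Compound 3 is therefore expected to give 15000 nM, within 5000 nM to 40000 nM, an expected step of no change at the digits printed from compound 2 to compound 3 (within the scatter).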

Compound 3, half-maximal cytotoxic concentration: 4000 nM
Beside the measured number, compound 3's estimate is 3.8-fold (0.57 log units) above it, outside the stated range (below it).
By their numbers in this assay, from the lowest: compound 3; then compounds 1 and 2 (each within the scatter of the next).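

Benzyl in place of propanoyl brings a 3.8-fold lower number from compound 2 to compound 3 (0.57 log units; beyond the scatter) in this assay and benzyl in place of methylsulfonyl brings a 3.8-fold lower number from compound 1 to compound 3 (0.57 log units; beyond the scatter) as well. The group on this nitrogen can therefore shift how much compound the cells tolerate, which the earlier swap of methylsulfonyl for propanoyl did not show. Nothing at hand explains the shift.

Still open, on these data alone, is whether the aromatic ring of benzyl matters or whether the loss of the carbonyl or sulfonyl is enough. A cyclohexylmethyl group, a simple ethyl chain or the free amine on this nitrogen would help separate these.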